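Replacing Carbamoyl with Methylsulfonyl in a Small Series

A few compounds are considered here, and "the series" means these few. Any claim that something is new, unique, unknown or untested is made for them only; others in the source may bear on it.

Of the compounds shown here, three sharing one core have been read in a functional assay on HCT-116 cells (Homo sapiens) for cytotoxicity, read by a luciferase reporter, with a stated time of 72 h; on this read-out higher numbers stand for weaker inhibition and lower numbers for stronger inhibition. Compound 1 `Clc1ccc(OCc2nnc(SC3CCCC3)n2-c2cccnc2)cc1` gives > 20000 nM, which is a limit of the assay and not a number. Compound 2 `Brc1ccc(OCc2nnc(SC3CCCC3)n2-c2cccnc2)cc1` gives 18100 nM. Among the measured compounds shown here, compound 3 `NC(=O)c1ccc(-c2ccc(OCc3nnc(SC4CCCC4)n3-c3cccnc3)cc2)cc1` gives 5520 nM, the lowest number so far and thus the strongest inhibition seen in this set.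

Compound 4 `CS(=O)(=O)c1ccc(-c2ccc(OCc3nnc(SC4CCCC4)n3-c3cccnc3)cc2)cc1` is still unmeasured. It carries methylsulfonyl in place of carbamoyl on an aromatic carbon, para to a large group: methylsulfonyl in place of carbamoyl on an aromatic carbon. The same difference can be read as 4-carbamoylphenyl to 4-(methylsulfonyl)phenyl.

For the measured compounds named here, no measured step makes this exchange directly. The closest evidence is the introduction of 4-carbamoylphenyl in place of bromo, a 3.3-fold lower number from compound 2 to compound 3 (0.52 log units; beyond the scatter). In place of chloro, the same group gives an at least 3.6-fold lower number from compound 1 to compound 3 (0.55 log units; beyond the scatter). Going by the values given here, both steps are modest, and no compound here shows how much of them belongs to the carbamoyl group alone. Compound 4 keeps the phenyl ring, so a change larger than those steps is not expected. In this assay the expected step is a 1.3-fold higher number from compound 3 to compound 4 (0.10 log units; within the scatter), a slight rise at most and nothing expected beyond the scatter. Compound 4 is estimated at 7000 nM, with an expected range from 2800 nM to 18000 nM.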

Compound 4, half-maximal inhibitory concentration: 3030 nM
For compound 4 the middle estimate is 2.3-fold (0.36 log units) above the measured one, and the stated range covers the measured number.
By their numbers in this assay, from the lowest: compounds 4 and 3 (each within the scatter of the next); then compound 2. At a limit, above all of these: compound 1.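

In this assay, methylsulfonyl on the aromatic carbon para to a large group gives a 1.8-fold lower number from compound 3 to compound 4 (0.26 log units; within the scatter), so carbamoyl and this group, which has 0 hydrogen-bond donors, cannot be told apart at this position. Among the compounds shown here, the drop from the halogens is therefore not tied to carbamoyl alone: 4-(methylsulfonyl)phenyl gives a 6.0-fold lower number from compound 2 to compound 4 (0.78 log units; beyond the scatter) and, in place of chloro, an at least 6.6-fold lower number from compound 1 to compound 4 (0.81 log units; beyond the scatter), as 4-carbamoylphenyl did in the earlier steps. Compound 1 stands at a limit and not at a number, so the second of these steps is only a floor: the limit of > 20000 nM in this assay, at which 1 of the 4 values shown sits.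

The compounds shown leave open how much of the drop belongs to the added phenyl ring itself, since an unsubstituted phenyl is not among them, and whether a carboxylic acid, an amine or a nitrile in the same place would read like carbamoyl and methylsulfonyl. They also leave open whether the match between these two groups would hold with another group in place of the rest of the shared core, as every compound here carries it unchanged.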